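The source may report more compounds than this note shows. Statements on the series, on what has been measured and on what is new or still open speak of the compounds shown alone.

Compound 1 `C=CC(=O)N1C(CC(=O)OCCCC)c2cccc(C)c2S1(=O)=O`: "not determined" (no result reported)
Compound 2 `CCCCOC(=O)CC1c2cccc(C)c2S(=O)(=O)N1C(=O)c1ccc(C)cc1`: "not determined" (no result reported)
Compound 3 `CCCCOC(=O)CC1c2cccc(C)c2S(=O)(=O)N1C(=O)c1ccc(C(F)(F)F)cc1`: 1310 nM

Of the three compounds tested in an assay on HEK-Blue hNOD1 cells for antagonist activity at Nucleotide-binding oligomerization domain-containing protein 1 (Homo sapiens), read by reporter gene assay, with stated times of 3 h and 20 h (on this read-out higher numbers stand for weaker inhibition and lower numbers for stronger inhibition), only compound 3 carries a number: in this assay compound 3 gives 1310 nM. Going by the values given here, for compound 1 and compound 2 no result was reported, so there is no second number to set beside compound 3 and no step between measured compounds can be drawn. Compound 3 therefore stands alone as the single reference point.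

Compound 4 `CCCCOC(=O)CC1c2cccc(C(=O)OCCCC)c2S(=O)(=O)N1C(=O)c1ccc(C(F)(F)F)cc1` is the next compound to be measured. It differs from compound 3 in one place: butoxycarbonyl in place of methyl on an aromatic carbon. The rest of the structure, the butyl ester chain on the ring system and the trifluoromethyl-bearing aroyl group on the sulfonamide nitrogen, is carried over unchanged.

Among the compounds with values here, with no step between measured compounds to lean on, the expectation for the step from compound 3 to compound 4 in this assay rests on the size of the change alone, and the step is expected to be small, within or close to the usual scatter, with no clear direction. Compound 4 is accordingly estimated to give 1600 nM in this assay, with a range from 400 nM to 6500 nM, which corresponds to an expected step of a 1.2-fold higher number from compound 3 to compound 4 (0.09 log units; within the scatter).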

Compound 4, half-maximal inhibitory concentration: 2930 nM
Compound 4: the middle estimate sits 1.8-fold (0.26 log units) below what was measured; the measured number falls inside the stated range.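

In this assay, exchanging methyl for butoxycarbonyl on this aromatic carbon gives a 2.2-fold higher number from compound 3 to compound 4 (0.35 log units; beyond the scatter) as a modest weakening of inhibition, one that lies beyond the usual scatter. The position is therefore not silent in this read-out, yet the change costs only part of the inhibition: compound 4 still gives a measured 2930 nM in the same assay despite carrying the much larger group, which brings in a carbonyl and a second butyl chain. No measured property of these compounds bears on the rise in the number, so the step stands without an explanation.

This single step cannot separate the contribution of the ester function from that of its butyl chain, and steps involving compound 1 and compound 2 cannot be read. A carboxylic acid, a methyl ester or a primary amide on the same aromatic carbon would tell these apart, while a plain hydrogen or a chlorine atom there would show whether the methyl of compound 3 contributes anything itself.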